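A few compounds are considered here, and "the series" means these few. Any claim that something is new, unique, unknown or untested is made for them only; others in the source may bear on it.

Compound 1 `Nc1ccccc1NC(=O)c1ccc(CNC2=N[C@H](Cc3ccccc3)CS2)cc1` carries a saturated ring whose single stereocentre is drawn R. In an assay on isolated protein for inhibition of protein deacetylase HDAC6 (Homo sapiens), read by fluorescence, with stated times of 3 h and 60 min (a higher number here means a weaker inhibitor, a lower number a stronger inhibitor), compound 1 gives > 20000 nM, which is a limit of the assay rather than a number. Compound 2 `Nc1ccccc1NC(=O)c1ccc(CNC2=NC[C@H](c3ccccc3)S2)cc1` in this assay gives "not determined" (no result reported). Compound 3 `Nc1cc(C(=O)O)ccc1NC(=O)c1ccc(CNc2nccc(-c3cccnc3)n2)cc1` in this assay gives > 20000 nM, again a limit. The evidence so far is the limit of > 20000 nM in this assay, at which 2 of the 3 values shown sit. Compound 4 `Nc1ccccc1NC(=O)c1ccc(CNC2=N[C@@H](Cc3ccccc3)CS2)cc1` differs from compound 1 only in configuration: the two compounds have the same atoms and bonds and differ only in configuration as drawn: 1 of 1 stereo elements differ; a stereocentre at a saturated ring carbon is drawn R in compound 1 and S in compound 4. Within the data shown here, with no measured step to lean on, compound 4 is expected to give 25000 nM, between 8000 nM and 80000 nM. That estimate means a change from compound 1 to compound 4 of a step that the limit leaves unreadable from compound 1 to compound 4, expected to be no more than the scatter, and most likely another limit.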

Compound 4, half-maximal inhibitory concentration: > 20000 nM
Compound 4 gave a limit, no number; the forecaster's own chance of this, stated with the estimate: 75%; the middle value does not contradict the limit.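

Among these compounds, compound 1 and compound 4 both stop at a limit of the assay, so no step between them can be read. The compounds shown leave open whether the configuration at the saturated ring carbon affects inhibition at all.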